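This account rests on a few compounds, and the source may have more. Where it says the series, first, only, none or still open, it means among the compounds named here.

Of the compounds shown here, three sharing one core have been measured in a physicochemical assay for lipophilicity, measured as octanol-water partition; a lower number here means a more polar compound, a higher number a more lipophilic compound. Compound 3 `C/C(=N\NC(=O)COc1cccc2ccccc12)c1ccccc1Br` gives 4.44, the second highest of the three numbers. Compound 1 `O=C(COc1cccc2ccccc12)N/N=C/c1ccccc1Br` gives 4.81 and compound 2 `C/C(=N\NC(=O)COc1cccc2ccccc12)c1ccccc1` gives 3.65, with both gaps to compound 3 beyond the usual scatter.

The next compound, compound 4 `C/C(=N\NC(=O)COc1cccc2ccccc12)c1ccccc1O`, changes a single group: hydroxy in place of bromo on an aromatic carbon. This is hydroxy in place of bromo on an aromatic carbon, ortho to a large group, so 2-bromophenyl becomes 2-hydroxyphenyl.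

Among the measured compounds shown here, only one measured step bears on this change. Bromo in place of hydrogen on an aromatic carbon gave a number 0.79 log units higher from compound 2 to compound 3 (beyond the scatter), a modest step. That step shows what adding the bromo did, and compound 4 no longer carries it. For the measured compounds named here, no measured compound carries a hydroxy, so the data cannot show what that group does here. Compound 2 is therefore the closest guide, and a fall in this assay of about the size of a number 0.79 log units higher from compound 2 to compound 3 (beyond the scatter) seems the most reasonable expectation, with real uncertainty on either side.

The expected change is a number 0.94 log units lower from compound 3 to compound 4 (beyond the scatter). For compound 4 the estimated value is 3.5, with an expected range from 3 to 4.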

Compound 4, partition coefficient: 3.08
Beside the measured number, compound 4's estimate is 0.42 log units above it; the range from low to high includes it.
By their numbers in this assay, from the lowest: compound 4; then compound 2; then compound 3; then compound 1.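

On this aromatic carbon, the hydroxy takes this assay the opposite way to the bromo: a number 0.57 log units lower from compound 2 to compound 4 (beyond the scatter) with hydroxy in place of hydrogen, whereas bromo in place of hydrogen gave a number 0.79 log units higher from compound 2 to compound 3 (beyond the scatter) in the earlier step. The two groups therefore lie on either side of the compound with only hydrogen there, and exchanging one for the other covers both distances, giving a number 1.36 log units lower from compound 3 to compound 4 (beyond the scatter) as the large step measured so far on this core. Nothing measured here explains why these two groups move the number in opposite directions.

Only hydrogen, bromo and hydroxy are shown on this carbon, so it remains open where a methoxy or an amine at the same place would fall relative to these three. On these data alone, it is also open whether exchanging bromo for hydroxy would give a step of similar size on the core of compound 1, which carries the same 2-bromophenyl group.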